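Aryl variation on the shared core: estimate for compound 4

The source may report more compounds than this note shows. Statements on the series, on what has been measured and on what is new or still open speak of the compounds shown alone.

Measured so far:
compound 1 `Cn1ccc2cc(-c3cc4nccc(-c5ccc(F)cc5)n4n3)ccc21` — 3520 nM
compound 2 `COc1cc(-c2ccnc3cc(-c4ccc(C(C)(C)C)cc4)nn23)cc(OC)c1OC` — > 10000 nM
compound 3 `COc1ccc(-c2cc3nccc(-c4cc(OC)c(OC)c(OC)c4)n3n2)cc1F` — 545 nM

Three compounds have been run in a functional assay on A549 cells (Homo sapiens) for inhibition, read by CCK-8 assay, with a stated time of 48 h; on this read-out lower numbers stand for stronger inhibition and higher numbers for weaker inhibition. Compound 1 gives 3520 nM and compound 3 gives 545 nM. For compound 2 the assay reports only a limit, > 10000 nM; compound 2 thus stands at the limit of > 10000 nM in this assay, at which 1 of the 3 values shown sits, and no number is known for it.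

Compound 4 `COc1cc(-c2ccnc3cc(-c4ccc(C)c(C)c4)nn23)cc(OC)c1OC` is the unmeasured analogue of compound 2. The change is 3,4-dimethylphenyl in place of 4-(tert-butyl)phenyl on an aromatic carbon.

For the measured compounds named here, the one measured step leaving compound 2 is an at least 18-fold lower number from compound 2 to compound 3 (1.26 log units; beyond the scatter), an aryl replacement on the same aromatic carbon. It shows that this replacement can move the number a long way, though with a different entering group. Only a modest step is therefore expected here, an at least 2.0-fold lower number from compound 2 to compound 4 (0.30 log units; that floor lies within the scatter). Compound 4 is estimated at 5000 nM, with a range of 1500 nM to 15000 nM.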

Compound 4, half-maximal inhibitory concentration: 272 nM
Estimate against measurement, compound 4: 18-fold (1.26 log units) above; the whole stated range lies above it.
By their numbers in this assay, from the lowest: compounds 4 and 3 (each within the scatter of the next); then compound 1. At a limit, above all of these: compound 2.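

In this assay the change from 4-(tert-butyl)phenyl to 3,4-dimethylphenyl gives an at least 36-fold lower number from compound 2 to compound 4 (1.56 log units; beyond the scatter) on this aromatic carbon, so a large step here does not require the fluoro and methoxy groups of compound 3. The two aryl groups entering at this carbon are not separated, with a 2.0-fold lower number from compound 3 to compound 4 (0.30 log units; within the scatter) within the scatter. Compound 2 is known only as a limit: the limit of > 10000 nM in this assay, at which 1 of the 4 values shown sits.

Still open, going by these compounds, is whether a single methyl group on the phenyl ring suffices. Also open, on these data alone, is how an amine or carboxylic acid on that ring would read.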